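The source may hold more compounds than are shown below. What is called first, only, known or untested is meant among the compounds shown, and "the series" means these compounds.

Among the compounds with values here, compound 2 `c1ccc(NCC2CCN(CCCc3c[nH]c4ccc(-n5cnnc5)cc34)CC2)nc1` gives 3.3 nM in an assay on CHO cells for displacement of a labelled ligand from 5-hydroxytryptamine receptor 1B (Homo sapiens) (a higher number here means a weaker inhibitor, a lower number a stronger inhibitor), the lower of the two numbers so far; compound 1 `CC(C)=CCN(C)C1CCN(CCCc2c[nH]c3ccc(-n4cnnc4)cc23)CC1` gives 41 nM in this assay. Within the data shown here, the only step known is a 12-fold lower number from compound 1 to compound 2 (1.09 log units; beyond the scatter), and it sits at the same saturated ring carbon that compound 3 `O[C@@H]1Cc2ccccc2[C@H]1NC1CCN(CCCc2c[nH]c3ccc(-n4cnnc4)cc23)CC1` alters: (2-hydroxy-2,3-dihydro-1H-inden-1-yl)amino in place of ((pyridin-2-yl)amino)methyl on a saturated ring carbon. That step shows this position can move the number a long way, but nothing measured shows the entering group itself, so the direction is uncertain. Compound 3 is therefore expected to stay close to its parent, at about 6 nM, between 1.5 nM and 25 nM, an expected step of a 1.8-fold higher number from compound 2 to compound 3 (0.26 log units; within the scatter).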

Compound 3, half-maximal inhibitory concentration: 210 nM
Compound 3: middle estimate off by 35-fold (1.54 log units), on the low side; measured number outside the range, above it.
By their numbers in this assay, from the lowest: compound 2; then compound 1; then compound 3.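

In this assay, placing (2-hydroxy-2,3-dihydro-1H-inden-1-yl)amino on the saturated ring carbon gives a 64-fold higher number from compound 2 to compound 3 (1.80 log units; beyond the scatter). It also gives a 5.1-fold higher number from compound 1 to compound 3 (0.71 log units; beyond the scatter), so this position can move the number upward as well as downward, and this group gives the highest number of the three substituents. Nothing available accounts for this change. The compounds shown leave open whether the hydroxy group or the five-membered carbon ring accounts for the higher number, and where a plain benzylamino group would fall on this carbon.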